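A few compounds are considered here, and "the series" means these few. Any claim that something is new, unique, unknown or untested is made for them only; others in the source may bear on it.

Measured so far in a functional assay for antagonist activity at Adrenergic receptor alpha-1 (Rattus norvegicus); a higher number here means weaker binding, a lower number tighter binding:
Compound 1 `COc1ccc(Cl)cc1N1CCN(CCNC(=O)c2cccnc2)CC1` — 2750 nM
Compound 2 `COc1ccc(Cl)cc1N1CCN(CCNC(=O)c2cc3ccccc3oc2=O)CC1` — 49 nM
Compound 3 `Cc1ccc(N2CCN(CCNC(=O)c3cccnc3)CC2)c(C)c1` — 1150 nM

Compound 3 holds the second highest number of the three. Its nearest neighbour is compound 1, whose higher number lies beyond the scatter; compound 2 stands furthest away, with a much lower number, also beyond the scatter. Only the aryl group on the ring nitrogen and the acyl part vary across the set, and compound 2 alone carries a different acyl part.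

Compound 4 `COc1ccc(N2CCN(CCNC(=O)c3cccnc3)CC2)cc1` is not yet measured in this assay. It differs from compound 3 in one place: 4-methoxyphenyl in place of 2,4-dimethylphenyl on an amine nitrogen in a ring. Compound 1 and compound 3 share the acyl part of compound 4 and both give weak numbers in this assay, so a swap of one aryl group for another within this set gives no ground to expect a large move. The step from compound 3 to compound 4 is expected to be small, a 1.3-fold higher number from compound 3 to compound 4 (0.12 log units; within the scatter), with no clear direction beyond the scatter. Compound 4 is estimated at 1500 nM, within 400 nM to 5000 nM.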

Compound 4, dissociation constant: 1620 nM
Compound 4: the middle estimate sits 1.1-fold (0.03 log units) below what was measured; low and high end bracket the measured number.
By their numbers in this assay, from the lowest: compound 2; then compounds 3, 4 and 1 (each within the scatter of the next, the first and the last beyond it).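

In this assay, for the compounds shown here, 4-methoxyphenyl in place of 2,4-dimethylphenyl on an amine nitrogen in a ring gives a 1.4-fold higher number from compound 3 to compound 4 (0.15 log units; within the scatter), the first step that changes one place only. With the acyl part held constant, this position therefore tolerates this exchange of aryl groups without a change beyond the scatter, even though the entering group carries a hydrogen-bond acceptor and the leaving group none. No measurement bearing on this result is available to account for it.

On these data alone, whether the same exchange stays within the scatter with the acyl part of compound 2 remains open. Also open, as far as these compounds go, is whether a phenyl group bearing an amine or a carboxylic acid at this position would behave like 4-methoxyphenyl.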